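Ketone series, pyridine ester to nitrile

The source may report more compounds than this note shows. Statements on the series, on what has been measured and on what is new or still open speak of the compounds shown alone.

Three ketones carrying the same phenyl-terminated chain on a small aromatic core have been measured in an assay on isolated protein for inhibition of neutral cholesterol ester hydrolase 1 (Homo sapiens); on this read-out higher numbers stand for weaker inhibition and lower numbers for stronger inhibition. Compound 1 `O=C(CCCCCCc1ccccc1)c1nc(-c2ccccn2)no1` gives 30000 nM in this assay. Compound 2 `O=C(CCCCCCc1ccccc1)c1ncon1` reaches only the limit of the assay, > 100000 nM. Compound 3 `COC(=O)c1cccc(-c2ccc(C(=O)CCCCCCc3ccccc3)nn2)n1` likewise reaches only the limit of the assay, > 100000 nM, so no number stands for it. Two of the three values therefore sit at this limit (the limit of > 100000 nM in this assay, at which 2 of the 3 values shown sit), and compound 3 stands among those with no measured number.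

Compound 4 `N#Cc1cccc(-c2ccc(C(=O)CCCCCCc3ccccc3)nn2)n1` differs from compound 3 in one place: cyano in place of methoxycarbonyl on an aromatic carbon. Within the data shown here, no step between measured compounds in this assay is available to calibrate such a change, and nothing among the three measured compounds speaks for a shift beyond the scatter in either direction. Compound 4 is therefore expected to remain near the limit, and the step of a number no higher from compound 3 to compound 4 (the limit leaves the size open) is estimated as none beyond the scatter. The estimate for compound 4 in this assay is 100000 nM, within 30000 nM to 300000 nM, with a substantial chance that again only a limit is reported.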

Compound 4, half-maximal inhibitory concentration: > 100000 nM
Compound 4 gave a limit, no number; the forecaster's own chance of this, stated with the estimate: 70%; the middle value lies on the limit itself.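

Compound 3 and compound 4 both end at a limit in this assay, not at a number, so no step can be read between them: the limit of > 100000 nM in this assay, at which 3 of the 4 values shown sit.

The compounds shown leave open how compound 3 and compound 4 rank against each other, and how far the true value of either lies from that limit.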